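Extending an amine substituent on an aromatic ring

The source may hold more compounds than are shown below. What is called first, only, known or untested is meant among the compounds shown, and "the series" means these compounds.

Measured compounds:
Compound 1, `CNc1ccc(C(=O)N2CCCCc3ccccc32)c(Cl)c1`, in an assay on HeLa cells for binding affinity to Vasopressin V2 receptor (Homo sapiens) (a lower number here means a stronger inhibitor, a higher number a weaker inhibitor), gives 35 nM.
Compound 2, `CN(C)c1ccc(C(=O)N2CCCCc3ccccc32)c(Cl)c1`, in this assay gives 18 nM.

Among these two values, compound 2 shows the lower number, but the single step connecting them, a 1.9-fold lower number from compound 1 to compound 2 (0.29 log units; within the scatter), does not exceed the scatter of repeated measurements, so the two compounds cannot be told apart with confidence.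

Compound 3, `CCN(CC)c1ccc(C(=O)N2CCCCc3ccccc32)c(Cl)c1`, has not yet been measured in this assay. It differs from compound 2 by diethylamino in place of dimethylamino on an aromatic carbon. For the measured compounds named here, the only measured step that bears on this change is the one from hydrogen to methyl on the same nitrogen, a 1.9-fold lower number from compound 1 to compound 2 (0.29 log units; within the scatter), which was small. Growing the two methyl groups into ethyl groups is a change of similar kind, so no shift beyond the scatter is expected in this assay, in either direction, for compound 3: the expected step is a 1.2-fold lower number from compound 2 to compound 3 (0.08 log units; within the scatter). The estimated value for compound 3 is 15 nM, with a range from 5 nM to 45 nM.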

Compound 3, half-maximal inhibitory concentration: 19 nM
Estimate against measurement, compound 3: 1.3-fold (0.10 log units) below; measured number inside the range.
By their numbers in this assay, from the lowest: compounds 2, 3 and 1 (each within the scatter of the next).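

Going from dimethylamino to diethylamino on this aromatic carbon in this assay gives a 1.1-fold higher number from compound 2 to compound 3 (0.02 log units; within the scatter) and so adds a second, larger change at this nitrogen that cannot be told from the scatter. The change from methylamino to diethylamino, the largest among these compounds, gives a 1.8-fold lower number from compound 1 to compound 3 (0.27 log units; within the scatter) and also stays within the scatter, so compounds 1, 2 and 3 cannot be separated in this assay, and the position tolerates all three amine groups. No separate measurement bears on why the number stays so flat across these groups.

On these data alone, whether a longer chain on the nitrogen, such as dipropylamino, or a ring amine, such as pyrrolidine, would move the number beyond the scatter remains open. The same holds for the plain amino group and for a replacement without nitrogen, such as methoxy.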